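The source may report more compounds than this note shows. Statements on the series, on what has been measured and on what is new or still open speak of the compounds shown alone.

Compound 3 `COc1cc(CNc2ncnc3c2ncn3[C@@H]2O[C@H](CO)[C@@H](O)[C@H]2O)cc(OC)c1` stands only at a limit in a functional assay on MCF cells (Homo sapiens) for antiproliferative activity, with a stated time of 72 h; on this read-out higher numbers stand for weaker inhibition and lower numbers for stronger inhibition: compound 3 gives > 166000 nM, which is a limit of the assay and not a number. Compound 1 `OC[C@H]1O[C@@H](n2cnc3c(NCc4ccc(Cl)cc4)ncnc32)[C@H](O)[C@@H]1O` likewise sits at a limit, giving > 166000 nM in this assay. Within the data shown here, compound 2 `OC[C@H]1O[C@@H](n2cnc3c(NCc4ccc(Cl)cc4Cl)ncnc32)[C@H](O)[C@@H]1O` gives 127000 nM in this assay, the one plain number in the set. The step of an at least 1.3-fold lower number from compound 1 to compound 2 (0.11 log units; that floor lies within the scatter) comes with chloro in place of hydrogen on an aromatic carbon. Among the measured compounds shown here, the step that the two limits leave unreadable from compound 1 to compound 3 cannot be read from its two limits, and the step of an at least 1.3-fold higher number from compound 2 to compound 3 (0.11 log units; that floor lies within the scatter) is the only readable step that reaches compound 3. What the set offers is mainly (the limit of > 166000 nM in this assay, at which 2 of the 3 values shown sit).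

Compound 4 `OC[C@H]1O[C@@H](n2cnc3c(NCc4ccc(C(F)(F)F)cc4)ncnc32)[C@H](O)[C@@H]1O` differs from compound 3 by 4-(trifluoromethyl)phenyl in place of 3,5-dimethoxyphenyl on a saturated chain carbon bound to a nitrogen on an aromatic ring. The 4-(trifluoromethyl)phenyl of compound 4 is closer in kind to the 4-chlorophenyl of compound 1 than to the 3,5-dimethoxyphenyl it replaces, and compound 1 itself reached only a limit. For the measured compounds named here, the only readable step on this aryl group, an at least 1.3-fold higher number from compound 2 to compound 3 (0.11 log units; that floor lies within the scatter), lies within the scatter. A step that the limit leaves unreadable from compound 3 to compound 4 is therefore expected, with a good chance that the assay again reports a limit rather than a number. Compound 4 is estimated at 170000 nM, between 60000 nM and 500000 nM.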

Compound 4, half-maximal inhibitory concentration: > 166000 nM
Compound 4 gave a limit, no number (the forecaster's own chance of this, stated with the estimate: 65%); the middle value is on the limit's open side.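

In this assay compound 4 gives > 166000 nM, which is a limit of the assay and not a number. Among these compounds, with 4-(trifluoromethyl)phenyl, a third aryl group on the saturated chain carbon bound to a nitrogen on an aromatic ring now reaches this limit, so the steps that join compound 4 to the other two limit compounds cannot be read, and the one readable step is an at least 1.3-fold higher number from compound 2 to compound 4 (0.11 log units; that floor lies within the scatter). At this position the series so far mostly records the ceiling of the read-out, and compound 2 remains the only compound with a plain number: the limit of > 166000 nM in this assay, at which 3 of the 4 values shown sit.

As far as these compounds go, whether that plain number marks a real difference from the compounds at the limit stays open. Also open, from the compounds shown here alone, is whether an amine or a carboxylic acid on the phenyl ring, or a longer chain in place of the saturated chain carbon, would give a plain number in this assay.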